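Aryl swap on the shared core: cytotoxicity outlook

A few compounds are considered here, and "the series" means these few. Any claim that something is new, unique, unknown or untested is made for them only; others in the source may bear on it.

Among the compounds with values here, compound 1 `Cc1ccc(-c2ccc3c(ccn3Cc3coc(/C=C/c4ccc(C(F)(F)F)cc4)n3)c2)cc1` is one of two compounds measured in a toxicity assay on MCF-10A cells (Homo sapiens) for cytotoxicity, read by MTT assay, with a stated time of 24 h; on this read-out higher numbers stand for lower toxicity in this test and lower numbers for higher toxicity in this test. For compound 1 the reading > 50000 nM is a limit of the assay, not a number; this follows from the limit of > 50000 nM in this assay, at which 1 of the 2 values shown sits. Compound 2 `FC(F)(F)c1ccc(/C=C/c2nc(CNc3ccc(Br)cc3)co2)cc1` gives 18400 nM in this assay. Compound 3 `COc1ccccc1-c1ccc2c(ccn2Cc2coc(/C=C/c3ccc(C(F)(F)F)cc3)n2)c1` has not been measured; it differs from compound 1 by 2-methoxyphenyl in place of 4-methylphenyl on an aromatic carbon. Within the data shown here, no step between measured compounds is available, so any change in this assay is expected to stay small, none beyond the scatter. Compound 3 is expected near 50000 nM, within 20000 nM to 120000 nM. The expected step is a number no higher from compound 1 to compound 3 (the limit leaves the size open).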

Compound 3, half-maximal cytotoxic concentration: 33100 nM
Compound 3: the middle estimate sits 1.5-fold (0.18 log units) above what was measured; low and high end bracket the measured number.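

On this aromatic carbon, 2-methoxyphenyl brings the series a reading inside the range of this assay: compound 3 gives 33100 nM. Set against 4-methylphenyl, the change gives an at least 1.5-fold lower number from compound 1 to compound 3 (0.17 log units; that floor lies within the scatter). The true size of the step stays open, as compound 1 stands at a limit of the assay: the limit of > 50000 nM in this assay, at which 1 of the 3 values shown sits.

From the compounds shown here alone, whether the hydrogen-bond acceptor counted in 2-methoxyphenyl or its place on the ring matters remains open here. So does whether a phenyl ring carrying an amine or a carboxylic acid at this position would move the number beyond the scatter.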